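Swapping the aryl group on the ring nitrogen of compound 3

This account rests on a few compounds, and the source may have more. Where it says the series, first, only, none or still open, it means among the compounds named here.

Of the compounds shown here, three sharing one core have been tested in a functional assay on MDA-MB-231 cells (Homo sapiens) for cytotoxicity, read by MTT assay, with a stated time of 72 h; on this read-out higher numbers stand for weaker inhibition and lower numbers for stronger inhibition. Compound 1 `COc1ccc(-n2nc(C(=O)Nc3ccc(Oc4ccnc5cc(OCCCN6CCCC6)c(OC)cc45)c(F)c3)c3ccccc3c2=O)cc1` gives 3450 nM. Compound 2 `COc1cc2c(Oc3ccc(NC(=O)c4nn(-c5ccccc5F)c(=O)c5ccccc45)cc3F)ccnc2cc1OCCCN1CCN(C)CC1` gives 1050 nM, and compound 3 `COc1cc2c(Oc3ccc(NC(=O)c4nn(-c5ccccc5F)c(=O)c5ccccc45)cc3F)ccnc2cc1OCCCN1CCCCC1` gives 910 nM. Compound 3 has the lowest number of the three, with compound 2 close by and compound 1 further off, beyond the usual scatter. Among the measured compounds shown here, the only single-point step among them, a 1.2-fold lower number from compound 2 to compound 3 (0.06 log units; within the scatter), shows that exchanging the amine at the end of the chain barely moved the read-out.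

Compound 4 `COc1ccc(-n2nc(C(=O)Nc3ccc(Oc4ccnc5cc(OCCCN6CCCCC6)c(OC)cc45)c(F)c3)c3ccccc3c2=O)cc1` is compound 3 with one change: 4-methoxyphenyl in place of 2-fluorophenyl on an aromatic nitrogen. For the measured compounds named here, no measured pair isolates this exact change. The nearest guide is compound 1, which carries the same 4-methoxyphenyl group as compound 4 but a different amine at the chain end, and shows a much higher number than compound 3. Since the amine swap between compound 2 and compound 3 mattered little, much of the gap between compound 1 and compound 3 plausibly tracks the aryl group, though this rests on a single comparison.

Compound 4 is therefore expected to land near 2800 nM, between 1200 nM and 6500 nM. The estimated step of a 3.1-fold higher number from compound 3 to compound 4 (0.49 log units; beyond the scatter) is expected to be a move toward weaker inhibition.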

Compound 4, half-maximal inhibitory concentration: 2010 nM
Estimate against measurement, compound 4: 1.4-fold (0.14 log units) above, and the stated range covers the measured number.
By their numbers in this assay, from the lowest: compounds 3, 2, 4 and 1 (each within the scatter of the next, the first and the last beyond it).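

In this assay, the change on the aromatic nitrogen can now be read directly: 4-methoxyphenyl in place of 2-fluorophenyl gives a 2.2-fold higher number from compound 3 to compound 4 (0.34 log units; beyond the scatter), a modest move toward weaker inhibition, with the piperidin-1-yl chain end held constant. The new pair with compound 1 gives a 1.7-fold lower number from compound 1 to compound 4 (0.23 log units; within the scatter), so piperidin-1-yl and pyrrolidin-1-yl cannot be told apart when 4-methoxyphenyl is present, just as the amine exchange in a 1.2-fold lower number from compound 2 to compound 3 (0.06 log units; within the scatter) stayed within the scatter when 2-fluorophenyl was present. Among these compounds, the aryl group on the ring nitrogen therefore shifts the read-out measurably, whereas neither amine exchange does, and no measurement is available to explain the step.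

Among the compounds shown here, with only two aryl groups to compare, the step cannot be divided between losing the fluorine and gaining the methoxy group, and a plain phenyl, 4-fluorophenyl or 2-methoxyphenyl group on this nitrogen would be needed to separate them. Going by these compounds, it also remains open whether the chain end stays this tolerant with a morpholin-4-yl or dimethylamino group, or with a longer chain.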